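The compounds below may be only part of what the source reports. "The series", "measured", "known", "first", "only" and "open" are said of these compounds alone.

Measured so far:
compound 1, `Oc1ccc(CNc2cc(C(F)(F)F)cc3[nH]ncc23)cc1` — 2550 nM
compound 2, `Oc1ccc(CNc2cc(C(F)(F)F)cc3[nH]ncc23)c(Cl)c1` — 2680 nM
compound 3, `Cc1ccc(CNc2cc(C(F)(F)F)cc3[nH]ncc23)c([N+](=O)O)c1` — 620 nM

In an assay for inhibition of Tryptophan 2,3-dioxygenase (Homo sapiens), with stated times of 10 min and 60 min (a lower number here means a stronger inhibitor, a higher number a weaker inhibitor), compound 1 stands second highest of the three numbers; compound 2 sits within the scatter of it, while compound 3 lies a good deal lower, beyond the scatter. Within the data shown here, the only single-place step recorded is a 1.1-fold higher number from compound 1 to compound 2 (0.02 log units; within the scatter), which shows that adding chloro on the 4-hydroxyphenyl leaves the number essentially unchanged. Among the measured compounds shown here, compound 3 carries two different groups on that phenyl in place of the hydroxyl, so its lower value cannot be split into separate contributions; its pairing with compound 1 has no single step and shows only that the two values differ.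

Compound 4, `FC(F)(F)c1cc(NCc2cccc(Br)c2)c2cn[nH]c2c1`, is yet to be measured in this assay. It differs from compound 1 as follows: 3-bromophenyl in place of 4-hydroxyphenyl on a saturated chain carbon bound to a nitrogen on an aromatic ring. The change removes the hydroxyl and places bromine on the phenyl; the nearest measured precedent is the chloro addition, which was within the scatter, while compound 3 shows that other substitution patterns on this phenyl can lower the number. For the measured compounds named here, no measured step covers loss of the hydroxyl itself. The expected step is therefore a 1.3-fold lower number from compound 1 to compound 4 (0.11 log units; within the scatter), with a broad range; the estimate for compound 4 is 2000 nM, between 600 nM and 7000 nM.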

Compound 4, half-maximal inhibitory concentration: 19100 nM
Beside the measured number, compound 4's estimate is 9.6-fold (0.98 log units) below it; measured number outside the range, above it.
By their numbers in this assay, from the lowest: compound 3; then compounds 1 and 2 (each within the scatter of the next); then compound 4.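

In this assay, among these compounds, the replacement of 4-hydroxyphenyl by 3-bromophenyl gives a 7.5-fold higher number from compound 1 to compound 4 (0.87 log units; beyond the scatter), so the group on the saturated chain carbon bound to a nitrogen on an aromatic ring can move the number beyond the scatter, whereas the only earlier single-place step, a 1.1-fold higher number from compound 1 to compound 2 (0.02 log units; within the scatter), stayed within it. The two groups match in heavy-atom count, with one six-membered aromatic ring of carbon only and no net charge, but the entering group has no hydrogen-bond donor or acceptor, and this single step cannot separate loss of the hydroxyl, arrival of the bromine and the different place of the substituent on the phenyl. No supporting data bear on the origin of this step.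

An unsubstituted phenyl, a 3-hydroxyphenyl and a 4-bromophenyl at this place would divide the step into those separate parts. As far as these compounds go, whether an aminophenyl or a carboxyphenyl could stand in for the hydroxyl here, keeping or improving on the number of compound 1, remains open.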